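This account rests on a few compounds, and the source may have more. Where it says the series, first, only, none or still open, it means among the compounds named here.

Compound 1 `CCCOC(=O)N1N=C(c2ccc(OC)cc2)CC1c1cc(OC)c(OC)c(OC)c1` in a functional assay on MDA-MB-231 cells (Homo sapiens) for antiproliferative activity, read by MTT assay, with a stated time of 48 h (on this read-out lower numbers stand for stronger inhibition of growth and higher numbers for weaker inhibition of growth), gives 20400 nM. For compound 2 `COc1ccc(C2=NN(C(=O)OCc3ccccc3)C(c3cc(OC)c(OC)c(OC)c3)C2)cc1` this assay reports only a limit, > 10000 nM. The change phenyl in place of ethyl on a saturated chain carbon bound to an oxygen next to a carbonyl group thus yields a step that the limit leaves unreadable from compound 1 to compound 2, the reading being blocked by the limit of > 10000 nM in this assay, at which 1 of the 3 values shown sits. Compound 3 `CCCOC(=O)N1N=C(c2cccc(O)c2)CC1c1cc(OC)c(OC)c(OC)c1` gives 10000 nM; the change 3-hydroxyphenyl in place of 4-methoxyphenyl on a carbon with a double bond to nitrogen yields a 2.0-fold lower number from compound 1 to compound 3 (0.31 log units; beyond the scatter), the only core difference between the two pairs. Compound 4 `COc1cc(C2CC(c3cccc(O)c3)=NN2C(=O)OCc2ccccc2)cc(OC)c1OC` is not yet measured. It differs from compound 3 by phenyl in place of ethyl on a saturated chain carbon bound to an oxygen next to a carbonyl group, the same change, at the same place, as that from compound 1 to compound 2. With the earlier step unreadable due to the limit of > 10000 nM in this assay, at which 1 of the 3 values shown sits, the expectation for compound 4 is weak and points toward the limit. Compound 4 is expected at 15000 nM, with a range of 6000 nM to 40000 nM. The expected step is a 1.5-fold higher number from compound 3 to compound 4 (0.18 log units; within the scatter).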

Compound 4, concentration for 50% growth inhibition: > 10000 nM
Compound 4 gave a limit, no number; the forecaster's own chance of this, stated with the estimate: 60%; the middle value lies beyond the limit too.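

In this assay compound 4 gives only a limit (> 10000 nM). On these data alone, on the core of compound 3, phenyl in place of ethyl gives a number no lower from compound 3 to compound 4 (the limit leaves the size open) and so brings no gain in growth inhibition, but the size of the step stays open. The steps from compound 1 to compound 2 and from compound 2 to compound 4 cannot be read, so it is not shown whether the change has the same size on both cores, the reading being blocked by one thing: the limit of > 10000 nM in this assay, at which 2 of the 4 values shown sit.

Open, as far as these compounds go, is how a butyl chain would read in place of propyl on either core. Also open, from the compounds shown here alone, is how a benzyl group carrying an amine or a carboxylic acid would read.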